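This account rests on a few compounds, and the source may have more. Where it says the series, first, only, none or still open, it means among the compounds named here.

The account follows three compounds tested in a functional assay on PC-3 cells (Homo sapiens) for inhibition, read by sulforhodamine B assay, with a stated time of 48 h; on this read-out higher numbers stand for weaker inhibition of growth and lower numbers for stronger inhibition of growth. Compound 1 `COC1=CC(=O)C(C/C=C(\C)CC/C=C(\C)CCC=C(C)C)=C(C)C1=O` returns no number in this assay but only a limit, > 30000 nM. Compound 2 `COC1=C(OC)[C@H](O)[C@H](C/C=C(\C)CC/C=C(\C)C[C@H](O)/C=C(\C)CO)[C@@H](C)C1=O` likewise returns only a limit, > 30000 nM. Compound 3 `COC1=C(OC)[C@H](OC(C)=O)[C@H](C/C=C(\C)CC/C=C(\C)C[C@H](O)/C=C(\C)C(=O)O)[C@@H](C)C1=O` also gives a limit rather than a number, > 30000 nM. Compound 3 therefore stands nowhere apart from the other two: all three rest at the same limit, (the limit of > 30000 nM in this assay, at which 3 of the 3 values shown sit), and none of them shows growth inhibition that the assay could quantify. Among the measured compounds shown here, no step between measured compounds can be drawn from these values, and nothing in them orders the three.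

The unmeasured compound 4 `COC1=C(OC)[C@H](OC(C)=O)[C@H](C/C=C(\C)CC/C=C(\C)C[C@@H]2C[C@@H](C)C(=O)O2)[C@@H](C)C1=O` follows from compound 3 by a single change: a group of 7 heavy atoms (5 carbon, 2 oxygen; one five-membered non-aromatic ring with 1 hetero atom) in place of a group of 8 heavy atoms (5 carbon, 3 oxygen; no ring), on a saturated chain carbon bound to a double-bonded chain carbon. The new group sits on a saturated chain carbon bound to a double-bonded chain carbon.

Every measured value is a limit, and the data give no direction for this change. Compound 4 is expected most likely to sit at the limit as well, and if a number does appear, the step of a number no higher from compound 3 to compound 4 (the limit leaves the size open) is expected to stay within the scatter rather than beyond it. The growth inhibition of compound 4 in this assay is estimated at 30000 nM, with a range from 10000 nM to 100000 nM.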

Compound 4, concentration for 50% growth inhibition: > 30000 nM
Compound 4 ended at the assay's limit; the forecaster's own chance of this, stated with the estimate: 80%; the middle value sits exactly at the limit.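

No step can be read from compound 3 to compound 4 in this assay, as both compounds give only a limit: the limit of > 30000 nM in this assay, at which 4 of the 4 values shown sit. The compounds shown leave open whether the group with the five-membered non-aromatic ring alters growth inhibition at all, and what value any of the four compounds would reach in this assay if measured beyond that limit.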